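From sec-butyl to butyl on a sulfur

This account rests on a few compounds, and the source may have more. Where it says the series, first, only, none or still open, it means among the compounds named here.

In an ADME assay on MT4 cells (Homo sapiens) for activation, read by MTT assay (on this read-out higher numbers stand for lower toxicity in this test and lower numbers for higher toxicity in this test), compound 3 `CCC(C)Sc1nc(O)c(C)c(C(C)c2c(F)cccc2F)n1` gives > 3000 nM, which is a limit and not a number. Compound 2 `Cc1c(O)nc(SC(C)C)nc1C(C)c1c(F)cccc1F` gives > 3000 nM, also a limit. Compound 1 `Cc1c(C(C)c2c(F)cccc2Cl)nc(SC2CCCC2)[nH]c1=O` gives > 15000 nM, again a limit. Compound 3 therefore has no exact place among these results. Compound 4 `CCCCSc1nc(O)c(C)c(C(C)c2c(F)cccc2F)n1` differs from compound 3 by one change: butyl in place of sec-butyl on a sulfur. For the measured compounds named here, the only measured step that bears on this change is a step that the two limits leave unreadable from compound 2 to compound 3, so it offers no size to carry over. No step beyond the scatter is expected in this assay, and the expected step runs a step that the limit leaves unreadable from compound 3 to compound 4. The estimated value for compound 4 is 5000 nM, with an expected range from 2500 nM to 25000 nM.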

Compound 4, half-maximal cytotoxic concentration: > 3000 nM
Compound 4 ended at the assay's limit (the forecaster's own chance of this, stated with the estimate: 80%); the middle value lies beyond the limit too.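

Compound 2, compound 3 and compound 4 all end at the same limit of the assay, so no step among them can be read: the limit of > 3000 nM in this assay, at which 3 of the 4 values shown sit.

From the compounds shown here alone, whether butyl, sec-butyl and isopropyl on the sulfur differ at all in this assay stays open.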